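Dichloroacetamides bearing a five-membered aromatic ring

This account rests on a few compounds, and the source may have more. Where it says the series, first, only, none or still open, it means among the compounds named here.

Compound 1 `O=C(Nc1cccc(-c2ccoc2)c1)C(Cl)Cl` is known in a functional assay on KB 3-1 cells (Homo sapiens) for cytotoxicity, read by MTT assay, with a stated time of 68 h (a lower number here means a stronger inhibitor, a higher number a weaker inhibitor), only as a limit of the assay, giving > 50000 nM, so its standing among the values at hand rests on the limit of > 50000 nM in this assay, at which 1 of the 2 values shown sits, alone. Compound 2 `COc1cccc(-c2cc(NC(=O)C(Cl)Cl)cc(-c3cccc(OC)c3)c2)c1` likewise reaches only a limit, > 30000 nM, as told by the limit of > 30000 nM in this assay, at which 1 of the 2 values shown sits. Compound 3 `O=C(Nc1cccc(-c2cccs2)c1)C(Cl)Cl` differs from compound 1 by thiophen-2-yl in place of furan-3-yl on an aromatic carbon. No measured step of this kind exists among these compounds, so the change is expected to bring no shift beyond the scatter in this assay, and compound 3 is expected to remain at a limit as well. Compound 3 is estimated at 50000 nM, within 15000 nM to 150000 nM, meaning a step of a number no higher from compound 1 to compound 3 (the limit leaves the size open).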

Compound 3, half-maximal inhibitory concentration: > 50000 nM
Compound 3: no number, only a limit (the forecaster's own chance of this, stated with the estimate: 85%); the middle value sits exactly at the limit.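

Within the data shown here, compound 1 and compound 3 are both known only as limits in this assay, and no step between them can be read. The compounds shown leave open whether thiophen-2-yl and furan-3-yl differ at all in this assay.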